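A few compounds are considered here, and "the series" means these few. Any claim that something is new, unique, unknown or untested is made for them only; others in the source may bear on it.

Compound 2 `COc1cc(C2CC(c3cc(OC)c(OC)c(OC)c3)=NN2C(C)=O)ccc1OCc1cn(Cc2ccc([N+](=O)[O-])cc2)nn1` carries a 3,4,5-trimethoxyphenyl group on the carbon of its five-membered core that is doubly bonded to nitrogen. In a functional assay on COLO 205 cells (Homo sapiens) for inhibition, read by sulforhodamine B assay, tested at 10 uM (a lower number here means less inhibition of growth, a higher number more inhibition of growth at the concentration tested), compound 2 gives 60%, the higher of the two numbers seen so far. Among the compounds with values here, its only neighbour is compound 1 `COc1cc(C2CC(c3ccc([N+](=O)[O-])cc3)=NN2C(C)=O)ccc1OCc1cn(Cc2ccc([N+](=O)[O-])cc2)nn1`, which in this assay gives 33%; the change from a 4-nitrophenyl group to the trimethoxyphenyl group brought a number 27 percentage points higher from compound 1 to compound 2 (beyond the scatter).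

Compound 3 `COc1ccc(C2=NN(C(C)=O)C(c3ccc(OCc4cn(Cc5ccc([N+](=O)[O-])cc5)nn4)c(OC)c3)C2)cc1` keeps everything else and alters that same position: 4-methoxyphenyl in place of 3,4,5-trimethoxyphenyl on a carbon with a double bond to nitrogen. Within the data shown here, no measured pair shows this particular swap, so the only guide is the step from compound 1 to compound 2, which shows that the group on this carbon can move the read-out by a modest amount. Removing two of the three methoxy groups is a change of similar scale at the same spot, and the expectation is that it undoes part of the gain rather than adding to it.

The estimated step from compound 2 to compound 3 is therefore a number 15 percentage points lower from compound 2 to compound 3 (beyond the scatter), a modest fall. Compound 3 is expected to give about 45%, within a range of 25% to 65%.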

Compound 3, percent growth inhibition at one concentration: 10%
Compound 3: the middle estimate sits 35 percentage points above what was measured, outside the stated range (below it).
By their numbers in this assay, from the lowest: compound 3; then compound 1; then compound 2.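

Taking away two of the three methoxy groups brought a number 50 percentage points lower from compound 2 to compound 3 (beyond the scatter) in this assay and this large step shows that the group on this carbon can move the read-out much further than the earlier pair revealed. A single methoxy group does not keep even part of the gain, since methoxy in place of nitro gave a number 23 percentage points lower from compound 1 to compound 3 (beyond the scatter) and left the 4-methoxyphenyl group under the 4-nitrophenyl group. Across these three compounds, the read-out therefore does not simply follow whether a methoxy group is present, and nothing available here explains why these groups differ so widely.

The compounds shown leave open which of the methoxy groups of the 3,4,5-trimethoxyphenyl group matter most, and whether a 3,4-dimethoxyphenyl or 3,5-dimethoxyphenyl group would stay near compound 2 or fall toward compound 3. They also leave open how a 4-aminophenyl or 4-carboxyphenyl group would behave on this carbon, and whether the same order would hold at other concentrations.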